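Sulfonamide series: pyridyl for pyrazinyl on the amide nitrogen

The source may hold more compounds than are shown below. What is called first, only, known or untested is meant among the compounds shown, and "the series" means these compounds.

Two members of the series have been measured in a functional assay on CHO cells for inhibition of Orexin/Hypocretin receptor type 1 (Homo sapiens), read by FLIPR and calcium flux; on this read-out lower numbers stand for stronger inhibition and higher numbers for weaker inhibition. Compound 1 `CCN(C(=O)CN(c1cc2c(C)nsc2cc1Cl)S(=O)(=O)c1ccc(OC)c(OC)c1)c1ccccn1` gives 8 nM in this assay. Compound 2 `CCN(C(=O)CN(c1cc(N(C)C)ccc1Cl)S(=O)(=O)c1ccc(OC)c(OC)c1)c1cnc(C)cn1` gives 5 nM in this assay. Compound 2 carries the lower of the two numbers, but the two values lie within the usual scatter of each other, so no order between compound 1 and compound 2 can be read from them.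

Compound 3 `CCN(C(=O)CN(c1cc(N(C)C)ccc1Cl)S(=O)(=O)c1ccc(OC)c(OC)c1)c1cccc(C)n1` has not yet been measured. It differs from compound 2 in one place: 6-methylpyridin-2-yl in place of 5-methylpyrazin-2-yl on an amide-type nitrogen. Among the compounds with values here, no measured pair isolates this change, so its size in this assay is unknown. Given that compound 2 gives 5 nM with a closely related shared core, the change from compound 2 to compound 3 is expected to stay within the scatter, that is a 1.2-fold higher number from compound 2 to compound 3 (0.08 log units; within the scatter), with no direction expected beyond it. Compound 3 is therefore estimated at 6 nM in this assay, in a range from 2 nM to 20 nM.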

Compound 3, half-maximal inhibitory concentration: 17 nM
Beside the measured number, compound 3's estimate is 2.8-fold (0.45 log units) below it; the measured number falls inside the stated range.
By their numbers in this assay, from the lowest: compounds 2 and 1 (each within the scatter of the next); then compound 3.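

Within the data shown here, the exchange on the amide-type nitrogen is the first single-place change that can be read, and in this assay it gives a 3.4-fold higher number from compound 2 to compound 3 (0.53 log units; beyond the scatter), so this position is sensitive to the identity of the aromatic ring it carries. The two groups have the same heavy-atom count and ring size, but the entering ring has 1 hetero atom and 1 hydrogen-bond acceptor where the leaving ring has 2 of each, so a small edit to the ring is enough to take the number beyond the scatter. Nothing available bears on the origin of this step, which therefore stands as an observation for this one pair on this one core.

The exchange alters the ring atoms and the placement of the methyl together, so the compounds shown do not separate the contributions of the two. Going by these compounds, how a phenyl or pyrimidinyl ring on the same nitrogen would read remains open, as does whether the step would keep its size on the core of compound 1.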